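Fluorinated aryl variant of a chromone-derived antiproliferative series

The source may report more compounds than this note shows. Statements on the series, on what has been measured and on what is new or still open speak of the compounds shown alone.

Going by the values given here, compound 2 `CCC1=C(O)c2c(oc(-c3cc(C)c(C)cc3C)cc2=O)C(CC)(CC)C1=O` gives 8.2 uM in a functional assay on KB cells (Homo sapiens) for antiproliferative activity, read by sulforhodamine B assay, with a stated time of 3 days (a lower number here means that less compound is needed, a higher number that more compound is needed for the effect), and holds the only number in this set. Compound 1 `CCC1=C(O)c2c(oc(-c3ccccc3)cc2=O)C(CC)(CC)C1=O` returns a limit in this assay, > 236 uM, which sits at the assay boundary rather than a number (the limit of > 236 uM in this assay, at which 1 of the 2 values shown sits). Compound 3 `CCC1=C(O)c2c(oc(-c3cc(C)ccc3F)cc2=O)C(CC)(CC)C1=O` differs from compound 2 by a single change: 2-fluoro-5-methylphenyl in place of 2,4,5-trimethylphenyl on an aromatic carbon. Among the compounds with values here, the one measured step that bears on this position, an at least 28-fold lower number from compound 1 to compound 2 (1.45 log units; beyond the scatter), shows that decorating the aryl ring matters greatly here. Since the entering 2-fluoro-5-methylphenyl group lies between phenyl and 2,4,5-trimethylphenyl in what it carries, a step toward a higher number than compound 2 is expected, yet smaller than the measured step. For compound 3 the expected step is a 3.7-fold higher number from compound 2 to compound 3 (0.56 log units; beyond the scatter). Compound 3 is therefore estimated at 30 uM, with a range from 8 uM to 150 uM.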

Compound 3, concentration for half-maximal effect: 47.3 uM
Beside the measured number, compound 3's estimate is 1.6-fold (0.20 log units) below it, and the stated range covers the measured number.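

In this assay, 2-fluoro-5-methylphenyl gives back part of what 2,4,5-trimethylphenyl gains at this position, with a 5.8-fold higher number from compound 2 to compound 3 (0.76 log units; beyond the scatter). It still keeps a clear advantage over the plain phenyl, with an at least 4.9-fold lower number from compound 1 to compound 3 (0.69 log units; beyond the scatter), so among these three compounds more than one decorated aryl ring improves on phenyl, and the size of the gain depends on what the ring carries. Compound 1 stands at a limit and not at a number, so this second step gives only a bound on the gain: the limit of > 236 uM in this assay, at which 1 of the 3 values shown sits.

Compound 3 differs from compound 2 in more than one substituent on the aryl ring, so the compounds shown do not separate the contribution of the fluorine from that of the methyl groups. On these data alone, how an aryl ring carrying a methoxy group, a chlorine or an amine would behave in this assay remains open.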